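The source may report more compounds than this note shows. Statements on the series, on what has been measured and on what is new or still open speak of the compounds shown alone.

Measured in a functional assay on HCT-116 cells (Homo sapiens) for cytotoxicity, with a stated time of 48 h; a lower number here means a stronger inhibitor, a higher number a weaker inhibitor:
- Compound 1 `COc1cccc(/C=C/C(=O)c2c(OC)cc(OC)cc2OC)c1`: 4300 nM
- Compound 2 `COc1cc(OC)c(C(=O)/C=C/c2ccc(Cl)cc2)c(OC)c1`: 5400 nM
- Compound 3 `COc1cc(OC)c(C(=O)/C=C/c2ccc(F)cc2)c(OC)c1`: 6200 nM

Compound 1 cannot be separated from the other two, since its value lies within the scatter of both: a 1.3-fold higher number from compound 1 to compound 2 (0.10 log units; within the scatter) and a 1.4-fold higher number from compound 1 to compound 3 (0.16 log units; within the scatter).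

Compound 4 `COc1cccc(/C=C/C(=O)c2c(O)cc(OC)cc2OC)c1` keeps the core of compound 1 but has hydrogen in place of methyl on an oxygen on an aromatic ring, methoxy to hydroxy (hydrogen in place of methyl on an oxygen on an aromatic ring). Going by the values given here, no measured step touches this oxygen, so the data give no direct size or direction for this change. The nearest guide is the replacement of 3-methoxyphenyl in compound 1, which elsewhere gave only a 1.3-fold higher number from compound 1 to compound 2 (0.10 log units; within the scatter) and a 1.4-fold higher number from compound 1 to compound 3 (0.16 log units; within the scatter). A step beyond the scatter is therefore not expected, and the estimated step is small: a 1.1-fold lower number from compound 1 to compound 4 (0.05 log units; within the scatter). For compound 4 the expected value is 3800 nM, with an estimated range from 1300 nM to 11000 nM.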

Compound 4, half-maximal inhibitory concentration: 7700 nM
Beside the measured number, compound 4's estimate is 2.0-fold (0.31 log units) below it; low and high end bracket the measured number.
By their numbers in this assay, from the lowest: compounds 1, 2, 3 and 4 (each within the scatter of the next).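

Going by these compounds alone, compound 4 gives the first reading at an oxygen on an aromatic ring of the shared core: methoxy to hydroxy there comes with a 1.8-fold higher number from compound 1 to compound 4 (0.25 log units; within the scatter) in this assay. This change therefore cannot be told apart from repeat measurement, so the methyl on this oxygen is not shown to matter for this read-out. Nothing at hand explains this reading.

As far as these compounds go, whether a longer chain on this oxygen, or an amine in its place, would give a step beyond the scatter stays open. So does whether the other methoxy groups on that ring would tolerate the same change.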